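The source may report more compounds than this note shows. Statements on the series, on what has been measured and on what is new or still open speak of the compounds shown alone.

Three analogues of one core are in hand. Compound 1 `O=C(NO)c1ccc(NCc2nc(-c3ccc(Cl)cc3)nn2-c2ccccc2)cc1` gives 181 nM in an assay on Sf9 cells for inhibition of protein deacetylase HDAC6 (Homo sapiens), read by fluorescence, with a stated time of 40 min; a higher number here means a weaker inhibitor, a lower number a stronger inhibitor; compound 2 `O=C(NO)c1ccc(NCc2nc(-c3ccccc3)nn2-c2cccc(Cl)c2)cc1` gives 678 nM in this assay, the highest number of the three; compound 3 `Cc1ccc(-c2nc(CNc3ccc(C(=O)NO)cc3)n(-c3ccccc3)n2)s1` gives 30.6 nM. Among the measured compounds shown here, the only single change measured, a 5.9-fold lower number from compound 1 to compound 3 (0.77 log units; beyond the scatter), alters the other aryl group and says nothing about the ring carrying the chloro group. Compound 4 `Cc1cccc(-n2nc(-c3ccccc3)nc2CNc2ccc(C(=O)NO)cc2)c1` differs from compound 2 by methyl in place of chloro on an aromatic carbon. Compound 1 and compound 2 differ in two places, so their values alone do not isolate this change. For the measured compounds named here, with no measured step bearing on it, little movement is expected: a 1.2-fold lower number from compound 2 to compound 4 (0.09 log units; within the scatter). For compound 4 the estimated value in this assay is 550 nM, range 200 nM to 1500 nM.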

Compound 4, half-maximal inhibitory concentration: 388 nM
For compound 4 the middle estimate is 1.4-fold (0.15 log units) above the measured one; the measured number falls inside the stated range.
By their numbers in this assay, from the lowest: compound 3; then compound 1; then compounds 4 and 2 (each within the scatter of the next).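

Among the compounds shown here, replacing 3-chlorophenyl with 3-methylphenyl gives the first measured single change on this ring (a 1.7-fold lower number from compound 2 to compound 4 (0.24 log units; within the scatter)). On a carbon meta to a large group, methyl and chloro therefore cannot be told apart in this pair. No supporting measurement bears on this result.

As far as these compounds go, whether an amine, a methoxy group or a carboxylic acid at this position would depart from the methyl and chloro values stays open. So does whether the same exchange would read alike on the other aryl group.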